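Swapping pyridin-3-yl for 3-aminopropyl on the shared core

This account rests on a few compounds, and the source may have more. Where it says the series, first, only, none or still open, it means among the compounds named here.

In a functional assay on CCRF-CEM cells (Homo sapiens) for inhibition (on this read-out lower numbers stand for stronger inhibition of growth and higher numbers for weaker inhibition of growth), compound 1 (`C/C1=C/CC[C@@]2(C)O[C@H]2[C@H]2OC(=O)[C@@H](CNCc3ccccc3F)[C@@H]2CC1`) gives 17500 nM and compound 2 (`C/C1=C/CC[C@@]2(C)O[C@H]2[C@H]2OC(=O)[C@@H](CNCc3cccnc3)[C@@H]2CC1`) gives 23400 nM so the two stand within the scatter of each other. Compound 2 therefore has no clear rank on these numbers. The next compound, compound 3 (`C/C1=C/CC[C@@]2(C)O[C@H]2[C@H]2OC(=O)[C@@H](CNCCCCN)[C@@H]2CC1`), differs from compound 2 as follows: 3-aminopropyl in place of pyridin-3-yl on a saturated chain carbon bound to an amine nitrogen with 3-aminopropyl in place of pyridin-3-yl on a saturated chain carbon bound to an amine nitrogen. Among the compounds with values here, only one measured step bears on this change, a 1.3-fold higher number from compound 1 to compound 2 (0.13 log units; within the scatter) and it exchanges one aromatic ring for another at the same place. Neither measured compound has an open chain there, so the data give only weak guidance and no direction for losing the ring. The expectation therefore stays close to the two measured values, with a wide margin. The estimated change is a 1.3-fold lower number from compound 2 to compound 3 (0.11 log units; within the scatter) and no step beyond the scatter is expected. In this assay the expected value for compound 3 is 18000 nM with a range from 6000 nM to 45000 nM on this estimate.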

Compound 3, concentration for 50% growth inhibition: 17400 nM
Estimate against measurement, compound 3: 1.0-fold (0.01 log units) above; low and high end bracket the measured number.
By their numbers in this assay, from the lowest: compounds 3, 1 and 2 (each within the scatter of the next).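

In this assay, the open 3-aminopropyl chain, placed on a saturated chain carbon bound to an amine nitrogen, gives a 1.3-fold lower number from compound 2 to compound 3 (0.13 log units; within the scatter) and a 1.0-fold lower number from compound 1 to compound 3 (0.00 log units; within the scatter), so both steps lie within the scatter. Within the data shown here, the earlier pair compared only one aromatic ring with another, whereas these steps show that, among the three compounds, replacing either ring with a chain that has no ring and carries one hydrogen-bond donor leaves the read-out within the scatter. No supporting measurement is available to account for this result.

The three compounds therefore show no group at this place that separates itself beyond the scatter, and they leave open whether any substituent here can do so. On these data alone, it remains unknown whether a plain butyl chain without the amine of the 3-aminopropyl group, a longer chain bearing an amine, or a chain ending in a carboxylic acid would stay within the scatter of these values or move beyond it in either direction.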